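The source may hold more compounds than are shown below. What is called first, only, known or untested is meant among the compounds shown, and "the series" means these compounds.

Working notes on the series. Compound 1 `Cn1cncc1C(OCc1ccc(C#N)cc1-c1cccc(Cl)c1)c1ccc(C#N)nc1` is tested in an assay on isolated protein (Bos taurus) for inhibition of geranylgeranyl transferase type-1 subunit beta (Homo sapiens) (a lower number here means a stronger inhibitor, a higher number a weaker inhibitor), where compound 1 gives 8620 nM. Of the two numbers recorded in this assay, this is the higher one; the nearest is compound 3 `Cn1cncc1C(OCc1ccc(C#N)c(-c2ccc(Cl)cc2)n1)c1ccc(C#N)cc1`, which in this assay gives 3900 nM, a lower number, and the gap between the two lies beyond the usual scatter. Compound 2 `Cn1cncc1C(OCc1ccc(C#N)nc1-c1ccccc1)c1ccc(C#N)cc1` in this assay gives > 10 nM, which is a limit of the assay and not a number, namely (the limit of > 10 nM in this assay, at which 1 of the 3 values shown sits). Among the measured compounds shown here, no step between two measured compounds that differ in a single place is recorded, so the set itself offers no measured guide to how a change on the pendant ring moves the number.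

Compound 4 `Cn1cncc1C(OCc1ccc(C#N)cc1-c1cc(Cl)cc(Cl)c1)c1ccc(C#N)nc1` differs from compound 1 in one place: chloro in place of hydrogen on an aromatic carbon. Cut one bond further out, the change reads as 3-chlorophenyl to 3,5-dichlorophenyl, the entering chloro standing meta to the existing chloro group and meta to a large group. Without a measured step of this kind, the expected step is a 1.4-fold lower number from compound 1 to compound 4 (0.16 log units; within the scatter), that is, a modest move toward a lower number or none beyond the scatter. Compound 4 is accordingly estimated at 6000 nM, with a range from 2000 nM to 20000 nM.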

Compound 4, half-maximal inhibitory concentration: 960 nM
Estimate against measurement, compound 4: 6.3-fold (0.80 log units) above, outside the stated range (below it).
By their numbers in this assay, from the lowest: compound 4; then compound 3; then compound 1.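

In this assay the series now has its first measured step between compounds that differ in one place: the change from 3-chlorophenyl to 3,5-dichlorophenyl gives a 9.0-fold lower number from compound 1 to compound 4 (0.95 log units; beyond the scatter) and so lies beyond the scatter. This shows that the aromatic carbon meta to the existing chloro group is not indifferent to substitution, since one added chloro, with the rest of the core of compound 1 unchanged, moves the number toward a stronger inhibitor. Among the compounds shown here, nothing recorded accounts for the size of this step, and the single limit among the values does not bear on it.

The compounds shown leave open whether this gain belongs to chloro itself or would also appear with a fluoro, methyl, methoxy or amine group on the same carbon. They also leave open whether the same change would move the number similarly on a compound with the other arrangement of ring nitrogen and nitrile, as one step on one pair cannot establish a pattern.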